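From pentyloxy to 4-hydroxybutyl on the chain

The source may report more compounds than this note shows. Statements on the series, on what has been measured and on what is new or still open speak of the compounds shown alone.

- compound 1 `COC(=O)CCCCCCCCCCCCCC/C=C1\CC(CO)(COC(=O)C(C)(C)C)OC1=O`: > 10 ug/mL
- compound 2 `CCCCCOCCCCCCC/C=C1\CC(CO)(COC(=O)C(C)(C)C)OC1=O`: 9.52 ug/mL

For the measured compounds named here, in a functional assay on NCI-H322 cells (Homo sapiens) for antiproliferative activity (a lower number here means a stronger inhibitor of growth, a higher number a weaker inhibitor of growth), compound 2 gives 9.52 ug/mL, the only actual number so far. Compound 1 is reported at > 10 ug/mL, which is a limit and not a number. Compound 3 `CC(C)(C)C(=O)OCC1(CO)C/C(=C\CCCCCCCCCCCO)C(=O)O1` has not yet been measured, and its change from compound 2 is 4-hydroxybutyl in place of pentyloxy on a saturated chain carbon, seven bonds along the chain from a double-bonded chain carbon. Going by the values given here, the only measured step is an at least 1.0-fold lower number from compound 1 to compound 2 (0.02 log units; that floor lies within the scatter), a floor within the scatter, so it sets no size for a change on this chain. Compound 2 also stands close to the limit of > 10 ug/mL in this assay, at which 1 of the 2 values shown sits, so compound 3 may be reported only as a limit. No shift beyond the scatter is expected in this assay, in either direction. The expected step is a 1.1-fold higher number from compound 2 to compound 3 (0.02 log units; within the scatter). For compound 3 the estimate is 10 ug/mL, with an expected range of 4 ug/mL to 25 ug/mL.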

Compound 3, concentration for 50% growth inhibition: > 10 ug/mL
Compound 3 was reported as a limit (the forecaster's own chance of this, stated with the estimate: 45%); the middle value sits exactly at the limit.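

In this assay, the change to 4-hydroxybutyl, which brings in a hydrogen-bond donor that pentyloxy lacks, gives an at least 1.0-fold higher number from compound 2 to compound 3 (0.02 log units; that floor lies within the scatter), so this first test of that donor on the chain sets no size for the change. The step from compound 1 to compound 3 cannot be read, as both values are limits and not numbers. Compound 2 therefore remains the only compound with an actual number, and the series now gathers at one ceiling: the limit of > 10 ug/mL in this assay, at which 2 of the 3 values shown sit.

Going by these compounds, whether compound 3 truly differs from compound 2 by more than the scatter stays open. Also open, on these data alone, is how an amine or a carboxylic acid in place of 4-hydroxybutyl, on the same saturated chain carbon, would read in this assay.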